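The compounds below may be only part of what the source reports. "The series", "measured", "known", "first", "only" and "open" are said of these compounds alone.

Working notes on the shared core of compound 1 `CCCSc1nc(N)c2nc(O)n(Cc3ccccc3)c2n1`. For the measured compounds named here, in a functional assay on the whole organism for activation, with Mus musculus as the target (on this read-out higher numbers stand for an effect only at larger amounts of compound and lower numbers for an effect already at smaller amounts), compound 1 gives 0.1 mg/kg, the lowest of the three numbers measured so far. Compound 2 `CCCCCNc1nc(N)c2nc(O)n(Cc3ccccc3)c2n1` gives 0.3 mg/kg in this assay, and compound 3 `CCCCCSc1nc(N)c2nc(O)n(Cc3ccccc3)c2n1` gives 1 mg/kg. Both measured steps away from compound 1 raise the number: a 3.0-fold higher number from compound 1 to compound 2 (0.48 log units; beyond the scatter) and a 10-fold higher number from compound 1 to compound 3 (1.00 log units; beyond the scatter). Between the other two compounds, a 3.3-fold higher number from compound 2 to compound 3 (0.52 log units; beyond the scatter).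

Compound 4 `CCCC[S+]([O-])c1nc(N)c2nc(O)n(Cc3ccccc3)c2n1` is not yet measured. Against compound 1 the change is a group of 6 heavy atoms (4 carbon, 1 oxygen, 1 sulfur; no ring) in place of a group of 4 heavy atoms (3 carbon, 1 sulfur; no ring), on an aromatic carbon. Going by the values given here, no measured pair reproduces this change. The two steps that leave compound 1 bear on it only loosely; both alter the group on the same aromatic carbon, and both gave a modest rise, a 3.0-fold higher number from compound 1 to compound 2 (0.48 log units; beyond the scatter) and a 10-fold higher number from compound 1 to compound 3 (1.00 log units; beyond the scatter). A modest rise beyond the scatter, toward a higher number in this assay, is therefore expected here too, with wide uncertainty. The number expected for compound 4 is 0.5 mg/kg, with a range from 0.15 mg/kg to 3 mg/kg. This corresponds to an expected step of a 5.0-fold higher number from compound 1 to compound 4 (0.70 log units; beyond the scatter).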

Compound 4, minimum effective dose: 1 mg/kg
For compound 4 the middle estimate is 2.0-fold (0.30 log units) below the measured one; measured number inside the range.
By their numbers in this assay, from the lowest: compound 1; then compound 2; then compounds 3 and 4 (each within the scatter of the next).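

At the aromatic carbon between two ring nitrogen atoms, putting the group of 6 heavy atoms, with its oxygen on sulfur, in place of pentylsulfanyl leaves this assay without a readable shift (no change at the digits printed from compound 3 to compound 4 (within the scatter)). The same group stands clear of propylsulfanyl (a 10-fold higher number from compound 1 to compound 4 (1.00 log units; beyond the scatter)) and of pentylamino (a 3.3-fold higher number from compound 2 to compound 4 (0.52 log units; beyond the scatter)). All three groups of 6 heavy atoms at this carbon therefore give higher numbers than propylsulfanyl, with no listed compound against this, while the sulfur-linked pair of compound 3 and compound 4 cannot be told apart.

No measurement at hand accounts for these steps.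

Butylsulfanyl would separate the contribution of the oxygen on sulfur from that of the chain, and propylamino would do the same for the linking atom at propyl length. Methylsulfanyl and ethylsulfanyl would show whether the numbers continue to fall with shorter chains.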